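Notes on the ring change from compound 2 to compound 4

This account rests on a few compounds, and the source may have more. Where it says the series, first, only, none or still open, it means among the compounds named here.

compound 1, `CCCOP(=O)(O)OCCSC(=S)N1CCCC1`, in a functional assay on DU-145 cells (Homo sapiens) for inhibition, read by MTT assay, with stated times of 18 h and 4 h; a lower number here means a stronger inhibitor, a higher number a weaker inhibitor: > 100000 nM, a limit of the assay rather than a number
compound 2, `CCCCCCCCCCOP(=O)(O)OCCSC(=S)N1CCCC1`, in this assay: 46100 nM
compound 3, `CCCCCCOP(=O)(O)OCCSC(=S)N1CCCCC1`, in this assay: > 100000 nM, a limit of the assay rather than a number

Going by the values given here, compound 2 holds the only number recorded in this assay; the other two entries sit at the limit of > 100000 nM in this assay, at which 2 of the 3 values shown sit. Among the compounds with values here, the single measured step, an at least 2.1-fold lower number from compound 1 to compound 2 (0.33 log units; beyond the scatter), concerns the chain on the oxygen side of the molecule and carries no information about the ring on the thiocarbonyl carbon. Compound 4, `CCCCCCCCCCOP(=O)(O)OCCSC(=S)N1CCN(C)CC1`, differs from compound 2 only there: 4-methylpiperazin-1-yl in place of pyrrolidin-1-yl on a thiocarbonyl carbon. Within the data shown here, no measured pair is separated by this change alone, so nothing supports a step beyond the scatter in either direction. The estimate for compound 4 in this assay is therefore 50000 nM, with a range from 20000 nM to 120000 nM. The expected step this corresponds to is a 1.1-fold higher number from compound 2 to compound 4 (0.04 log units; within the scatter). Since the range overlaps (the limit of > 100000 nM in this assay, at which 2 of the 3 values shown sit), a limit rather than a number remains a real possibility for compound 4.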

Compound 4, half-maximal inhibitory concentration: 82300 nM
Estimate against measurement, compound 4: 1.6-fold (0.22 log units) below; low and high end bracket the measured number.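

In this assay, 4-methylpiperazin-1-yl in place of pyrrolidin-1-yl on a thiocarbonyl carbon gives a 1.8-fold higher number from compound 2 to compound 4 (0.25 log units; within the scatter). Going by these compounds alone, this is the first reading at this position: with the chain on the oxygen side held fixed, a six-membered ring with 2 hetero atoms and 1 hydrogen-bond acceptor and a five-membered ring with 1 hetero atom and no acceptor cannot be told apart here. Compound 4 also gives a number rather than a limit, although part of the series sits at that limit: the limit of > 100000 nM in this assay, at which 2 of the 4 values shown sit.

This single pair does not show whether the result holds with any other chain on the oxygen side. From the compounds shown here alone, how an open-chain diethylamino group or a morpholin-4-yl ring would read at this thiocarbonyl carbon also remains open.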